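Swapping amino for methoxy on a pyrazole chalcone

The compounds below may be only part of what the source reports. "The series", "measured", "known", "first", "only" and "open" are said of these compounds alone.

Three compounds share a core in which a pyrazole carries one aryl ring and is linked through an unsaturated ketone to a second aryl ring. Compound 1 `COc1cc(-c2cc(/C=C/C(=O)c3ccc(N)cc3)[nH]n2)cc(OC)c1OC` was tested in a functional assay on NCI-H226 cells (Homo sapiens) for cytotoxicity, read by sulforhodamine B assay, with a stated time of 48 h, tested at 0.01 uM (on this read-out higher numbers stand for a weaker effect at the one concentration tested and lower numbers for a stronger effect), and gave 92%. Compound 2 `COc1ccc(-c2cc(/C=C/C(=O)c3cc(OC)c(OC)c(OC)c3)[nH]n2)cc1OC` gave 93% in this assay, and compound 3 `COc1ccc(-c2cc(/C=C/C(=O)c3ccc(N)cc3)[nH]n2)cc1` gave 102%. Compound 1 thus has the smallest of the three numbers, yet both other values lie within the usual scatter of it, so the three show no real difference: at this low concentration none of them has a clear effect on cell growth.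

Compound 4 `COc1ccc(C(=O)/C=C/c2cc(-c3cc(OC)c(OC)c(OC)c3)n[nH]2)cc1` differs from compound 1 in one place: methoxy in place of amino on an aromatic carbon. Within the data shown here, no measured pair shows this change, so its effect here is unknown, but with all three known values sitting near the level of untreated cells there is little room for a shift in either direction. Compound 4 is therefore expected to read close to compound 1, with a step of a number 4 percentage points higher from compound 1 to compound 4 (within the scatter) that stays within the scatter. The estimate for compound 4 in this assay is 96%, ranging from 85% to 106%.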

Compound 4, a percentage reported as activity, at one concentration (the size of the read-out at that concentration, not a potency): 99%
Estimate against measurement, compound 4: 3 percentage points below; the measured number falls inside the stated range.
By their numbers in this assay, from the lowest: compounds 1, 2, 4 and 3 (each within the scatter of the next).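

Among these compounds, replacing the 4-aminophenyl of compound 1 with 4-methoxyphenyl gives the first direct reading of this change, and in this assay it amounts to a number 7 percentage points higher from compound 1 to compound 4 (within the scatter). At this one low concentration, then, exchanging amino for methoxy, para to a large group, leaves no difference that can be told from ordinary assay scatter, even though the exchange removes a hydrogen-bond donor and adds a heavy atom. No supporting measurement is available to explain this reading.

On these data alone, whether a hydroxyl or a dimethylamino group at this place would read any differently remains open. Also open, as far as these compounds go, is whether amino and methoxy would separate at concentrations where these compounds clearly reduce cell growth, so this flat result cannot show that the position is unimportant.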